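The source may hold more compounds than are shown below. What is called first, only, known or untested is meant among the compounds shown, and "the series" means these compounds.

Values measured in a functional assay on VCaP cells (Homo sapiens) for antiproliferative activity, read by propidium iodide staining, with a stated time of 96 h; on this read-out lower numbers stand for stronger inhibition and higher numbers for weaker inhibition:
- compound 1 `CC(O)(COc1cccc(S(F)(F)(F)(F)F)c1)C(=O)Nc1cccc(S(F)(F)(F)(F)F)c1`: 26700 nM
- compound 2 `CC(O)(COc1cccc(C(F)(F)F)c1)C(=O)Nc1cccc(S(F)(F)(F)(F)F)c1`: 22500 nM
- compound 3 `CC(O)(COc1cccc(OC(F)(F)F)c1)C(=O)Nc1cccc(S(F)(F)(F)(F)F)c1`: 28600 nM

Compound 2 is not separated from the other two compounds: a 1.2-fold lower number from compound 1 to compound 2 (0.07 log units; within the scatter), and a 1.3-fold higher number from compound 2 to compound 3 (0.10 log units; within the scatter). The next compound is compound 4 `CC(O)(COc1ccc(C#N)c(F)c1)C(=O)Nc1cccc(S(F)(F)(F)(F)F)c1`, where the change from compound 2 is 4-cyano-3-fluorophenyl in place of 3-(trifluoromethyl)phenyl on an oxygen on a saturated carbon. The measured steps that bear on it are those above and a 1.1-fold higher number from compound 1 to compound 3 (0.03 log units; within the scatter). All exchange one group on an aromatic carbon, and all stay within the scatter. None tests a nitrile, so they are only a partial guide. No step beyond the scatter is therefore expected in this assay, and the expected change is a 1.1-fold lower number from compound 2 to compound 4 (0.05 log units; within the scatter). For compound 4 the estimate is 20000 nM, with an expected range of 8000 nM to 40000 nM.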

Compound 4, half-maximal inhibitory concentration: 91900 nM
The estimate for compound 4 lay 4.6-fold (0.66 log units) below the measured number, outside the stated range (above it).
By their numbers in this assay, from the lowest: compounds 2, 1 and 3 (each within the scatter of the next); then compound 4.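

With the group on the oxygen on a saturated carbon, 4-cyano-3-fluorophenyl in place of 3-(trifluoromethyl)phenyl gives in this assay a step of a 4.1-fold higher number from compound 2 to compound 4 (0.61 log units; beyond the scatter) in the weaker direction. The earlier exchanges of one group on an aromatic carbon all stayed within the scatter, so this is the first change shown to separate compounds at this position. No measurement available here accounts for the step. The nitrile and the fluorine enter together, and the compounds shown do not separate their contributions. From the compounds shown here alone, how an amine or a carboxylic acid on this ring would read out remains open.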